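The compounds below may be only part of what the source reports. "The series", "measured", "known", "first", "only" and "open" are said of these compounds alone.

Of the compounds shown here, three have been measured in a functional assay on SH-SY5Y cells (Homo sapiens) for cytotoxicity, read by MTT assay, with stated times of 8 h, 30 min and 12 h, tested at 0.5 uM; a lower number here means a weaker effect, a higher number a stronger effect of the compound at the concentration tested. Compound 1 `N=C(NCc1ccccc1)[C@@H]1CCC(=O)N1Cc1ccccc1[N+](=O)[O-]` gives 28.8%. Compound 2 `N=C(NCc1ccc(O)cc1)[C@@H]1CCC(=O)N1Cc1ccccc1[N+](=O)[O-]` carries one change relative to compound 1, (hydroxy in place of hydrogen on an aromatic carbon), and in this assay compound 2 gives 26.9%, a step of a number 1.9 percentage points lower from compound 1 to compound 2 (within the scatter). Compound 3 `N=C(NCc1ccccc1)[C@@H]1CCC(=O)N1Cc1ccc([N+](=O)[O-])cc1` has the same atoms as compound 1 joined differently; the difference between the two cores is not broken down here. In this assay compound 3 gives 24%. Compound 4 `N=C(NCc1ccc(O)cc1)[C@@H]1CCC(=O)N1Cc1ccc([N+](=O)[O-])cc1` has not yet been measured; it differs from compound 3 by hydroxy in place of hydrogen on an aromatic carbon, the same change seen between compound 1 and compound 2. Because the earlier step of a number 1.9 percentage points lower from compound 1 to compound 2 (within the scatter) stayed within the scatter, the step of a number 2 percentage points lower from compound 3 to compound 4 (within the scatter) is expected to be small as well. Compound 4 is estimated at 22%, between 14% and 30%.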

Compound 4, a percentage reported as activity, at one concentration (the size of the read-out at that concentration, not a potency): 31.3%
Estimate against measurement, compound 4: 9.3 percentage points below; measured number above the stated range.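

In this assay, hydroxy in place of hydrogen on an aromatic carbon gives a number 7.3 percentage points higher from compound 3 to compound 4 (within the scatter), and 4-nitrophenyl in place of 2-nitrophenyl gives a number 4.4 percentage points higher from compound 2 to compound 4 (within the scatter). Set side by side, the two hydroxy steps do not differ: the same change on two cores in this assay, a number 1.9 percentage points lower (within the scatter) from compound 1 to compound 2 and a number 7.3 percentage points higher (within the scatter) from compound 3 to compound 4, 9.2 percentage points apart, within the scatter of two such steps. The change therefore carries from one core to the other without a difference that can be told apart in this read-out, but two pairs, with both steps within the scatter, do not show that hydroxy has any effect here or that the step would hold on other cores.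

The compounds shown leave open how a methoxy group or an amine would read in place of the hydroxy. They also leave open how a carboxylic acid would read in place of the nitro group.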